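The source may hold more compounds than are shown below. What is called first, only, known or untested is meant among the compounds shown, and "the series" means these compounds.

Measured compounds:
- compound 1, `O=C(/C(=C\c1c[nH]c2ccccc12)S(=O)(=O)Cc1ccc(F)cc1)c1ccc(Cl)cc1`: 50000 nM
- compound 2, `Cc1ccc(CS/C(=C/c2ccccc2F)C(=O)c2ccc(Cl)cc2)cc1`: 10000 nM
- compound 3, `Cc1ccc(CS/C(=C/c2ccccc2OCc2ccccc2)C(=O)c2ccc(Cl)cc2)cc1`: 1000 nM

In a functional assay on DU-145 cells (Homo sapiens) for inhibition, read by trypan blue exclusion, with a stated time of 96 h (on this read-out higher numbers stand for weaker inhibition of growth and lower numbers for stronger inhibition of growth), compound 2 gives 10000 nM and stands second highest of the three numbers. Compound 1 gives 50000 nM, a higher number than compound 2, while compound 3 gives 1000 nM, the lowest of the three. Compound 1 differs from compound 2 in several places at once, so its value is only a point of reference.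

The unmeasured compound 4, `Cc1ccc(CS/C(=C/c2ccc(Cl)cc2)C(=O)c2ccc(Cl)cc2)cc1`, is reached from compound 2 by a single change: 4-chlorophenyl in place of 2-fluorophenyl on a double-bonded chain carbon bound to a double-bonded chain carbon.

Within the data shown here, the only measured step on the same ring is a 10-fold lower number from compound 2 to compound 3 (1.00 log units; beyond the scatter). That step replaced the fluoro with a much larger group and gave a modest gain; compound 4 instead carries a different halogen in a different position on the same ring, so the step does not transfer directly. Among the measured compounds shown here, a change of substituent on this ring has, on the one comparison available, moved the number downward, and a smaller move in the same direction is the working expectation for compound 4 in this assay, namely a 3.3-fold lower number from compound 2 to compound 4 (0.52 log units; beyond the scatter).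

Compound 4 is therefore estimated at 3000 nM, with a range of 800 nM to 15000 nM.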

Compound 4, concentration for 50% growth inhibition: 10000 nM
The estimate for compound 4 lay 3.3-fold (0.52 log units) below the measured number; measured number inside the range.
By their numbers in this assay, from the lowest: compound 3; then compounds 2 and 4 (each within the scatter of the next); then compound 1.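

In this assay, 4-chlorophenyl in place of 2-fluorophenyl on a double-bonded chain carbon bound to a double-bonded chain carbon gives no change at the digits printed from compound 2 to compound 4 (within the scatter), so a change of aryl group at this position does not by itself move the number. Among the changes shown at this carbon, only benzyloxy in place of fluoro, with a 10-fold lower number from compound 2 to compound 3 (1.00 log units; beyond the scatter), moves the number beyond the scatter, and the halogen exchange does not share that effect even though the step alters both the halogen and the name of its ring position. No measurement here accounts for the absence of a shift at this carbon, and the two groups match in the heavy-atom count, so nothing beyond the step itself can be stated.

Open, on these data alone, is whether 2-chlorophenyl or 4-fluorophenyl at this carbon would read like the two halogen compounds, since those groups would separate the identity of the halogen from its placement. Also open, as far as these compounds go, is whether the lower number of compound 3 depends on the benzyl part of the benzyloxy group, which a methoxy group or a 2-aminophenyl group at the same carbon would begin to test.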